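Side-chain change on the shared core

The source may hold more compounds than are shown below. What is called first, only, known or untested is meant among the compounds shown, and "the series" means these compounds.

Measured in a functional assay (trachea) with Cavia porcellus as the target; on this read-out higher numbers stand for an effect only at larger amounts of compound and lower numbers for an effect already at smaller amounts:
- compound 1 `CCCn1c(=O)n(CCC(N)=O)c(=O)c2[nH]cnc21` gives 13100 nM
- compound 2 `CCCn1c(=O)n(CCCN(C)C)c(=O)c2[nH]cnc21` gives 20500 nM

Compound 2 lies within the scatter of compound 1, so neither stands apart so far. Unmeasured compound 3 `CCCn1c(=O)n(CCO)c(=O)c2[nH]cnc21` differs from compound 2 by hydroxy in place of (dimethylamino)methyl on a saturated chain carbon, two bonds along the chain from an aromatic nitrogen as its single change. For the measured compounds named here, the only measured step at that place is a 1.6-fold higher number from compound 1 to compound 2 (0.19 log units; within the scatter) and it involves the same (dimethylamino)methyl group. Going by the values given here, no hydroxy compound has been measured, so this is thin evidence. No step beyond the scatter is expected in this assay in either direction. The expected step is a 1.3-fold lower number from compound 2 to compound 3 (0.11 log units; within the scatter) on this estimate. Compound 3 is estimated at 16000 nM within a range from 6000 nM to 42000 nM for now.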

Compound 3, half-maximal effective concentration: 510 nM
For compound 3 the middle estimate is 31-fold (1.50 log units) above the measured one, outside the stated range (below it).
By their numbers in this assay, from the lowest: compound 3; then compounds 1 and 2 (each within the scatter of the next).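

In this assay this position proves responsive to what ends the chain: hydroxy gives a 40-fold lower number from compound 2 to compound 3 (1.60 log units; beyond the scatter) and, in place of carbamoyl, a 26-fold lower number from compound 1 to compound 3 (1.41 log units; beyond the scatter), whereas the two earlier compounds stayed within the scatter of each other. Of the three side chains, only the 2-hydroxyethyl chain of compound 3 stands apart. Nothing available here bears on the reason for these steps.

The change swaps the end group and shortens the chain together, so the two remain unseparated. A 3-hydroxypropyl chain, or a methoxy or primary amine on the two-carbon chain, would tell them apart.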